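The source may report more compounds than this note shows. Statements on the series, on what has been measured and on what is new or still open speak of the compounds shown alone.

Measured so far:
compound 1, `COc1ccc(-n2nc(Sc3ccc(Cl)cc3)cc(CC[C@@H](C)NC(=O)[C@H]3CCNC[C@@H]3c3ccc(Cl)cc3)c2=O)cc1`, in a functional assay with Melanocortin receptor 4 (Homo sapiens) as the target, read by cAMP accumulation (a lower number here means that less compound is needed, a higher number that more compound is needed for the effect), gives 150 nM;
compound 2, `COc1ccc(-n2nc(Sc3ccc(Cl)cc3)cc(CC[C@@H](C)NC(=O)[C@H]3CCNC[C@@H]3c3ccc(F)cc3)c2=O)cc1`, in this assay gives 110 nM.

These two differ only in one halogen, and the step of a 1.4-fold lower number from compound 1 to compound 2 (0.13 log units; within the scatter) lies within the scatter, so compound 2 stands together with compound 1 rather than apart from it. Compound 3, `COc1ccc(-n2nc(Sc3ccc(Cl)cc3)cc(CC[C@@H](C)NC(=O)[C@H]3CCNC[C@@H]3c3ccccc3F)c2=O)cc1`, is not yet measured. It changes the same ring: 2-fluorophenyl in place of 4-fluorophenyl on a saturated ring carbon. Among the measured compounds shown here, the only measured step swaps one halogen for another at the same spot and moves nothing; no step shows a fluorine moved round its ring. There is thus no basis for a step beyond the scatter, and the expected step of a 1.1-fold higher number from compound 2 to compound 3 (0.04 log units; within the scatter) is small. Compound 3 is estimated at 120 nM, within 50 nM to 300 nM.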

Compound 3, half-maximal effective concentration: 550 nM
Estimate against measurement, compound 3: 4.6-fold (0.66 log units) below; measured number above the stated range.
By their numbers in this assay, from the lowest: compounds 2 and 1 (each within the scatter of the next); then compound 3.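

On this ring carbon, the place of the halogen on the phenyl group matters more in this assay than the choice of halogen: 2-fluorophenyl in place of 4-fluorophenyl gives a 5.0-fold higher number from compound 2 to compound 3 (0.70 log units; beyond the scatter) and so goes beyond the scatter, which the swap of chlorine for fluorine did not. The comparison with 4-chlorophenyl points the same way, with a 3.7-fold higher number from compound 1 to compound 3 (0.56 log units; beyond the scatter) in this pair. No measurement here explains why moving the fluorine has this effect.

Still open, as far as these compounds go, is how a 3-fluorophenyl group would read. Also open, from the compounds shown here alone, is whether 2-chlorophenyl would follow 2-fluorophenyl, or whether an unsubstituted phenyl would stand closer to the 4-substituted compounds.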